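A few compounds are considered here, and "the series" means these few. Any claim that something is new, unique, unknown or untested is made for them only; others in the source may bear on it.

Measured in an ADME assay on microsomes from liver (Mus musculus) for metabolic stability, read by LC-MS, with a stated time of 40 min, tested at 0.5 uM; on this read-out lower numbers stand for slow clearance and higher numbers for fast clearance:
- Compound 1 `CC(C)(C)NS(=O)(=O)c1cccc(NC(=O)c2ccc(NS(=O)(=O)C3(C)CC3)cc2N2CCC3(CC2)CC3)c1`: 90 mL.min-1.g-1
- Compound 2 `CC(C)(O)CNc1ccc(C(=O)Nc2cccc(S(=O)(=O)C3CCCC3)n2)c(N2CCC3(CC2)CC3)c1`: > 399 mL.min-1.g-1 (a limit of the assay, not a number)

Compound 2 gives > 399 mL.min-1.g-1, so it sits at the limit of the assay, on the fast-clearance side. Compound 3 `O=C(Nc1cccc(S(=O)(=O)C2CCCC2)n1)c1ccc(NCCO)cc1N1CCC2(CC1)CC2` carries hydroxymethyl in place of 1-hydroxy-1-methylethyl on a saturated chain carbon bound to a nitrogen on an aromatic ring. Within the data shown here, no measured pair of compounds shows this kind of change. In this assay the expected move, an at least 1.3-fold lower number from compound 2 to compound 3 (0.12 log units; that floor lies within the scatter), is small and, if anything, towards slower clearance. For compound 3 the estimated value is 300 mL.min-1.g-1, with an expected range of 120 mL.min-1.g-1 to 600 mL.min-1.g-1.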

Compound 3, intrinsic clearance in microsomes: > 399 mL.min-1.g-1
Compound 3: only a limit was reported; the forecaster's own chance of this, stated with the estimate: 35%; middle value at least 1.3-fold (0.12 log units) from the limit.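

Compound 2 and compound 3 both give only a limit in this assay, not a number, so no step can be read between them: the limit of > 399 mL.min-1.g-1 in this assay, at which 2 of the 3 values shown sit.

As far as these compounds go, whether hydroxymethyl in place of 1-hydroxy-1-methylethyl changes clearance at all stays open.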